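Ring size of the chain amine: compound 1 to compound 4

A few compounds are considered here, and "the series" means these few. Any claim that something is new, unique, unknown or untested is made for them only; others in the source may bear on it.

Compound 1: `COc1cc2c(Oc3ccc(NC(=O)c4nn(-c5ccccc5F)c(=O)c5ccccc45)cc3F)ccnc2cc1OCCCN1CCCC1` — 140 nM
Compound 2: `COc1cc2c(Oc3ccc(NC(=O)c4nn(-c5ccc(Br)cc5)c(=O)c5ccccc45)cc3F)ccnc2cc1OCCCN1CCCC1` — 230 nM
Compound 3: `COc1cc2c(Oc3ccc(NC(=O)c4nn(-c5ccccc5Br)c(=O)c5ccccc45)cc3F)ccnc2cc1OCCCN1CCCC1` — 410 nM

The three compounds were measured in a functional assay on MKN-45 cells (Homo sapiens) for cytotoxicity, read by MTT assay, with a stated time of 72 h; a higher number here means a weaker inhibitor, a lower number a stronger inhibitor. Compound 1 has the lowest of the three numbers; compound 2 stands nearest to it, with a step of a 1.6-fold higher number from compound 1 to compound 2 (0.22 log units; within the scatter), and compound 3 stands furthest, with a step of a 2.9-fold higher number from compound 1 to compound 3 (0.47 log units; beyond the scatter). Between compound 2 and compound 3 the step is a 1.8-fold higher number from compound 2 to compound 3 (0.25 log units; within the scatter). All three steps concern only the group on the aromatic nitrogen of the shared core.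

Compound 4, `COc1cc2c(Oc3ccc(NC(=O)c4nn(-c5ccccc5F)c(=O)c5ccccc45)cc3F)ccnc2cc1OCCCN1CCCCC1`, differs from compound 1 elsewhere: piperidin-1-yl in place of pyrrolidin-1-yl on a saturated chain carbon, three bonds along the chain from an oxygen on an aromatic ring. Within the data shown here, no measured step touches this part of the molecule, so none of the three steps bears on the change. With nothing in the data to point either way, the expected outcome in this assay is a step no larger than the scatter, in no set direction, and the step from compound 1 to compound 4 is estimated at a 1.2-fold higher number from compound 1 to compound 4 (0.08 log units; within the scatter). Compound 4 is therefore expected to give about 170 nM in this assay, within a range from 70 nM to 420 nM.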

Compound 4, half-maximal inhibitory concentration: 350 nM
Compound 4: middle estimate off by 2.1-fold (0.31 log units), on the low side; the measured number falls inside the stated range.
By their numbers in this assay, from the lowest: compounds 1, 2, 4 and 3 (each within the scatter of the next, the first and the last beyond it).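

Among these compounds, the chain amine proves to be a position that matters in this assay: with piperidin-1-yl in place of pyrrolidin-1-yl, the step is a 2.5-fold higher number from compound 1 to compound 4 (0.40 log units; beyond the scatter), whereas the earlier compounds varied only the group on the aromatic nitrogen. With the 2-fluorophenyl group held fixed, the six-membered ring gives the higher number of this pair, so the far end of the 3-(pyrrolidin-1-yl)propyl chain also bears on this read-out. Nothing measured here accounts for the step.

Still open, on these data alone, is how the same ring change reads with the 4-bromophenyl or 2-bromophenyl group on the aromatic nitrogen. Also open, as far as these compounds go, is how a morpholine, a dimethylamino group or a longer chain carrying pyrrolidin-1-yl would compare with compound 1.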